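Changing one carbonyl substituent on compound 3

This account rests on a few compounds, and the source may have more. Where it says the series, first, only, none or still open, it means among the compounds named here.

Of the compounds shown here, three have been measured so far in a functional assay on Coronary artery (Bos taurus) (a higher number here means that more compound is needed for the effect, a lower number that less compound is needed), and compound 1 `CCCCCNC(=O)NCCCC/C=C\CCCCCNS(=O)(=O)c1ccccc1` gives 3400 nM there. In this assay compound 2 `CCCCCNC(=O)NCCCC/C=C\CCCCCS(=O)(=O)c1ccccc1O` gives 5000 nM and compound 3 `CCCCNC(=O)C(=O)NCCCC/C=C\CCCCCCc1noc(=S)[nH]1` gives 360 nM as the lowest of the three numbers, with its gap to each of the others beyond the scatter.

Compound 4 `CCCCCNC(=O)NCCCC/C=C\CCCCCCc1noc(=S)[nH]1` differs from compound 3 at one place pentylamino in place of butylcarbamoyl on a carbonyl carbon with pentylamino in place of butylcarbamoyl on a carbonyl carbon. Within the data shown here, the only measured step, which is a 1.5-fold higher number from compound 1 to compound 2 (0.17 log units; within the scatter), makes a different change, (2-hydroxyphenyl)sulfonyl in place of (phenylsulfonyl)amino, so it says nothing direct about this swap. Compound 1 at 3400 nM also carries pentylamino on a carbonyl carbon, as does compound 2, but both differ from compound 3 elsewhere as well, so their higher numbers cannot be assigned to this change. The data therefore give no measured size for it, and compound 4 is best anchored on compound 3, which it most closely resembles. The expected step is a 1.4-fold higher number from compound 3 to compound 4 (0.14 log units; within the scatter) and no shift beyond the scatter is expected, though a rise is the likelier direction. Compound 4 is expected at 500 nM with an estimated range from 110 nM to 2500 nM on this reading.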

Compound 4, half-maximal effective concentration: 3300 nM
Compound 4: middle estimate off by 6.6-fold (0.82 log units), on the low side; the measured number lies above the stated range.
By their numbers in this assay, from the lowest: compound 3; then compounds 4, 1 and 2 (each within the scatter of the next).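

The change of butylcarbamoyl to pentylamino on this carbonyl carbon gives a 9.2-fold higher number from compound 3 to compound 4 (0.96 log units; beyond the scatter) in this assay and thus provides the first measured size for any change at this position. Compound 4 keeps the five-membered ring group of compound 3, yet the swaps of the group on the saturated chain carbon give a 1.0-fold lower number from compound 1 to compound 4 (0.01 log units; within the scatter) and a 1.5-fold lower number from compound 2 to compound 4 (0.18 log units; within the scatter), both within the scatter. Among the pentylamino compounds, then, these end groups do not separate, and the ring group alone does not carry the low number of compound 3, which depends on what stands on the carbonyl carbon.

The step changes the chain and removes a carbonyl at once, so the compounds shown do not tell which of the two matters; butylamino or pentylcarbamoyl on the same carbonyl carbon would separate them. Whether the butylcarbamoyl group would also lower the number with the sulfonyl end groups of compound 1 and compound 2 remains open too, and no measurement shown offers an account of the step.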